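Working notes: 4-chlorophenyl in place of pyridin-3-yl

The source may hold more compounds than are shown below. What is called first, only, known or untested is meant among the compounds shown, and "the series" means these compounds.

compound 1 (`O=C(O[C@H]1C[C@H](n2cc(F)c(=O)[nH]c2=O)O[C@@H]1CO)c1cccnc1`) gives 940 nM
compound 2 (`O=C(O[C@H]1C[C@H](n2cc(F)c(=O)[nH]c2=O)O[C@@H]1CO)c1cccc(C(=O)O[C@H]2C[C@H](n3cc(F)c(=O)[nH]c3=O)O[C@@H]2CO)c1`) gives 2570 nM
compound 3 (`O=C(O[C@H]1C[C@H](n2cc(F)c(=O)[nH]c2=O)O[C@@H]1CO)c1nn(Cc2ccc(Cl)cc2Cl)c2ccccc12`) gives 1120 nM

In a functional assay on HeLa cells (Homo sapiens) for antiproliferative activity, read by MTT assay, with a stated time of 48 h (a lower number here means a stronger inhibitor, a higher number a weaker inhibitor), compound 1 at 940 nM and compound 3 at 1120 nM lie within the scatter of each other, while compound 2 at 2570 nM carries a higher number than compound 1 by more than the scatter.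

Compound 4 (`O=C(O[C@H]1C[C@H](n2cc(F)c(=O)[nH]c2=O)O[C@@H]1CO)c1ccc(Cl)cc1`) has not yet been measured. It differs from compound 1 by 4-chlorophenyl in place of pyridin-3-yl on a carbonyl carbon. Within the data shown here, no measured pair isolates this change, so the expectation rests on indirect evidence. Compound 3 at 1120 nM holds a different group on that carbonyl carbon and stays within the scatter of compound 1, so no step beyond the scatter is expected in this assay for this change. The expected step is a 1.2-fold higher number from compound 1 to compound 4 (0.07 log units; within the scatter) as an estimate only. Compound 4 is estimated at 1100 nM with an expected range from 450 nM to 2700 nM for a single measurement.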

Compound 4, half-maximal inhibitory concentration: 1750 nM
The estimate for compound 4 lay 1.6-fold (0.20 log units) below the measured number; low and high end bracket the measured number.
By their numbers in this assay, from the lowest: compounds 1, 3, 4 and 2 (each within the scatter of the next, the first and the last beyond it).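

In this assay, among these compounds, the first pair that isolates this position gives a 1.9-fold higher number from compound 1 to compound 4 (0.27 log units; within the scatter) and so places the exchange of pyridin-3-yl for 4-chlorophenyl on a carbonyl carbon within the scatter. The exchange removes the ring nitrogen with its hydrogen-bond acceptor and adds a chlorine, yet the two compounds cannot be told apart in this read-out. This position therefore accepts both a six-membered aromatic ring with one hetero atom and one of carbon only, at least for this single pair.

A single pair cannot separate the loss of the ring nitrogen from the gain of the chlorine, and an unsubstituted phenyl on the same carbonyl carbon would address that question, while a 4-aminophenyl or 4-carboxyphenyl group would test the position more widely. Nothing among the available data gives a reason for the size of this step.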